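A phenyl ring in place of a pyrimidine: expected solubility

This account rests on a few compounds, and the source may have more. Where it says the series, first, only, none or still open, it means among the compounds named here.

For the measured compounds named here, compound 3 `Cc1cc(NCc2ccccn2)n2ncc(-c3cncnc3)c2n1` is the one member of this small set with an actual number in a physicochemical assay for solubility, read by HPLC, using the shake flask method, measured as kinetic solubility, with a stated time of 2 h, at pH 7.4 (a higher number here means a more soluble compound, a lower number a less soluble compound), where compound 3 gives 111000 nM. Compound 1 `Cc1cc(NCc2ccccn2)n2ncc(-c3ccc(N(C)C)cc3)c2n1` gives only a limit in this assay, < 5000 nM. Compound 2 `Cc1cc(NCc2ccccn2)n2ncc(-c3ccc(F)cc3F)c2n1` likewise gives only a limit, < 5000 nM. Compound 4 `Cc1cc(NCc2ccccn2)n2ncc(-c3ccc(F)cc3C)c2n1` has not been measured; it differs from compound 3 by 4-fluoro-2-methylphenyl in place of pyrimidin-5-yl on an aromatic carbon. The two measured steps that bear on this change run the other way: an at least 22-fold higher number from compound 1 to compound 3 (1.34 log units; beyond the scatter) and an at least 22-fold higher number from compound 2 to compound 3 (1.34 log units; beyond the scatter), both starting from the limit (the limit of < 5000 nM in this assay, at which 2 of the 3 values shown sit). Going back from pyrimidin-5-yl to 4-fluoro-2-methylphenyl, compound 4 is therefore expected to show a large fall, a 37-fold lower number from compound 3 to compound 4 (1.57 log units; beyond the scatter). Compound 4 is estimated at 3000 nM, with a range from 500 nM to 15000 nM.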

Compound 4, solubility: 42300 nM
Compound 4: the middle estimate sits 14-fold (1.15 log units) below what was measured; measured number above the stated range.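

In this assay, a ring of carbon only at this position does not by itself bring the number down to the limit: the step from pyrimidin-5-yl is only a 2.6-fold lower number from compound 3 to compound 4 (0.42 log units; beyond the scatter). The groups on that ring make a clear difference, with an at least 8.4-fold higher number from compound 2 to compound 4 (0.92 log units; beyond the scatter) and an at least 8.4-fold higher number from compound 1 to compound 4 (0.92 log units; beyond the scatter). Both of these steps start from a limit, not a number: the limit of < 5000 nM in this assay, at which 2 of the 4 values shown sit.

The step between compound 1 and compound 2 cannot be read. As far as these compounds go, how a phenyl ring bearing a carboxylic acid or a methoxy group would read at this position stays open.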